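The source may report more compounds than this note shows. Statements on the series, on what has been measured and on what is new or still open speak of the compounds shown alone.

Working notes on the series. Compound 1 `c1ccc(-c2cnccn2)c(OCC2=NCCN2)c1` carries pyrazin-2-yl on the shared core; in a functional assay for activation of Alpha-1A adrenergic receptor (Homo sapiens), read by calcium flux (on this read-out higher numbers stand for an effect only at larger amounts of compound and lower numbers for an effect already at smaller amounts), compound 1 gives 2.51 nM. Compound 2 `c1ccc(-c2ccncn2)c(OCC2=NCCN2)c1` carries pyrimidin-4-yl in that place. For compound 2 this assay reports only a limit, < 100000 nM, so compound 2 has no resolved position among the numbers shown. Among the measured compounds shown here, the step that the limit leaves unreadable from compound 1 to compound 2 therefore cannot be sized; the only evidence bearing on it is the limit of < 100000 nM in this assay, at which 1 of the 2 values shown sits. Compound 3 `c1coc(-c2ccccc2OCC2=NCCN2)c1` differs from compound 2 by furan-2-yl in place of pyrimidin-4-yl on an aromatic carbon. For the measured compounds named here, no measured step covers this change, and the one step that exists is unreadable, so it gives no guide to direction or size. Compound 3 is expected to land with a wide range around 100 nM (from 3 nM to 3000 nM) in this assay. Against compound 2 this estimate means an expected step that the limit leaves unreadable from compound 2 to compound 3.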

Compound 3, half-maximal effective concentration: 1.26 nM
Compound 3: middle estimate off by 79-fold (1.90 log units), on the high side; measured number below the stated range.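

In this assay, the place on the aromatic carbon now holds two different aromatic rings with values that stay within the scatter of each other: a 2.0-fold lower number from compound 1 to compound 3 (0.30 log units; within the scatter). Furan-2-yl, a five-membered aromatic ring with 1 hetero atom, therefore serves here as well as the six-membered pyrazin-2-yl, which compound 1 on its own could not show. Compound 2 remains a limit of the assay, and the steps that touch it cannot be read: the limit of < 100000 nM in this assay, at which 1 of the 3 values shown sits.

The compounds shown leave open where compound 2 stands on the numerical scale, and so whether pyrimidin-4-yl truly differs from the other two rings. They also leave open whether a hetero atom is needed in this place at all, as a plain phenyl or an open chain such as methoxy would test.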